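The compounds below may be only part of what the source reports. "The series", "measured", "known", "first", "only" and "open" are said of these compounds alone.

Measured so far in an assay on isolated protein for binding affinity to Equilibrative nucleoside transporter 1 (Homo sapiens); on this read-out higher numbers stand for weaker inhibition and lower numbers for stronger inhibition:
compound 1 `O=[N+]([O-])c1cccc2c1CCN(c1ncnc3c1ncn3[C@@H]1O[C@H](CO)[C@@H](O)[C@H]1O)C2` gives 3020 nM
compound 2 `CC(C)c1ccc(CSc2ncnc3c2ncn3[C@@H]2O[C@H](CO)[C@@H](O)[C@H]2O)cc1` gives 4790 nM
compound 3 `Nc1nc(SCc2ccc(Br)cc2)c2ncn([C@@H]3O[C@H](CO)[C@@H](O)[C@H]3O)c2n1` gives 813 nM

Compound 3 holds the lowest number of the three; its gap to compound 1 and its gap to compound 2 both lie beyond the usual scatter, so on this read-out it is the strongest inhibitor among the measured compounds. Within the data shown here, no two measured compounds differ in a single place, so no step between them can be read off directly, and compound 1 and compound 2 can only be set side by side as two numbers.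

Compound 4 `CC(C)Sc1nc(N)nc2c1ncn2[C@@H]1O[C@H](CO)[C@@H](O)[C@H]1O` is the untested analogue of compound 3. The change is isopropyl in place of 4-bromobenzyl on a sulfur. The shared core is kept unchanged. Among the measured compounds shown here, nothing measured shows what exchanging the 4-bromobenzyl group for the isopropyl group does in this assay; the only comparison at hand, compound 2 against compound 3, differs in more than one place and gives no reading on the sulfur substituent alone. A weakening is expected, roughly a 4.9-fold higher number from compound 3 to compound 4 (0.69 log units; beyond the scatter), with wide uncertainty. Compound 4 is estimated at 4000 nM, with a range from 1000 nM to 20000 nM.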

Compound 4, half-maximal inhibitory concentration: 191000 nM
Estimate against measurement, compound 4: 48-fold (1.68 log units) below, and the stated range ends below it.
By their numbers in this assay, from the lowest: compound 3; then compounds 1 and 2 (each within the scatter of the next); then compound 4.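

In this assay, the sulfur substituent gives the series its first reading of a single change: isopropyl in place of 4-bromobenzyl produces a 230-fold higher number from compound 3 to compound 4 (2.37 log units; beyond the scatter), a large step well beyond the scatter. For this pair, the group on the sulfur therefore has a strong bearing on the measured inhibition, and the aromatic ring and bromine of the 4-bromobenzyl group cannot be lost together without a heavy weakening, while the shared core stays unchanged. No measurement at hand bears on the reason for a step of this size.

The step removes the bromine, the six-membered aromatic ring and the methylene link in one move, so it cannot assign the weakening to any one of them, and this single pair sets no trend for other groups on the sulfur. An unsubstituted benzyl group would separate the bromine from the ring, while a straight butyl chain or a cyclohexylmethyl group on the same sulfur would show whether a larger group without an aromatic ring recovers any of the lost inhibition.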